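Hydroxy to Bromo on a Shared Amide Core

The compounds below may be only part of what the source reports. "The series", "measured", "known", "first", "only" and "open" are said of these compounds alone.

The account concerns compound 1 `COc1ccc(-c2cnc(NC(=O)c3cccc(O)c3)n2C)cc1` and compound 2 `COc1ccc(-c2cccc(NC(=O)c3ccc(F)cc3)n2)cc1`, both examined in a toxicity assay on THP-1 cells (Homo sapiens) for inhibition; on this read-out higher numbers stand for lower toxicity in this test and lower numbers for higher toxicity in this test. For compound 1 the assay returned only a limit, > 100000 nM, and no number. For compound 2 the assay likewise reported only a limit, > 100000 nM. Compound 1 thus stands at the limit of > 100000 nM in this assay, at which 2 of the 2 values shown sit, and it cannot be placed in any order against compound 2. Compound 3 `COc1ccc(-c2cnc(NC(=O)c3cccc(Br)c3)n2C)cc1` has not yet been tested. It differs from compound 1 by bromo in place of hydroxy on an aromatic carbon, that is, 3-hydroxyphenyl becomes 3-bromophenyl. Among the compounds with values here, no step between measured compounds exists to guide the size of this change. Because every value shown sits at the limit of > 100000 nM in this assay, at which 2 of the 2 values shown sit, the step of a number no higher from compound 1 to compound 3 (the limit leaves the size open) is expected to be none beyond the scatter. Compound 3 is accordingly estimated at 100000 nM, within a range from 30000 nM to 300000 nM, and the assay will most probably again report only a limit.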

Compound 3, half-maximal cytotoxic concentration: > 100000 nM
Compound 3 ended at the assay's limit (the forecaster's own chance of this, stated with the estimate: 70%); the middle value lies on the limit itself.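

In this assay compound 1 and compound 3 both give only limits and no numbers, so no step can be read for bromo in place of hydroxy on an aromatic carbon. The compounds shown leave open how far apart they truly lie, and which change to the shared core would bring a value off the limit: the limit of > 100000 nM in this assay, at which 3 of the 3 values shown sit.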